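Thiocarbamate amide series: tetrahydroquinoline swapped for an open amine

The source may report more compounds than this note shows. Statements on the series, on what has been measured and on what is new or still open speak of the compounds shown alone.

Of the compounds shown here, three sharing one benzamide core have been measured in a functional assay on HeLa cells (Homo sapiens) for antiproliferative activity, read by CCK-8 assay, with a stated time of 72 h, tested at 2 uM; a higher number here means a stronger effect of the compound at the concentration tested, a lower number a weaker effect. Compound 1 `Nc1ccccc1NC(=O)c1ccc(CSC(=S)N2CCN(Cc3ccccn3)CC2)cc1` gives 14.2%. Compound 2 `Nc1ccccc1NC(=O)c1ccc(CSC(=S)N2CCCc3ccccc32)cc1` gives 26.1%. Compound 3 `N#Cc1ccc(N2CCN(C(=S)SCc3ccc(C(=O)Nc4ccccc4N)cc3)CC2)cc1` gives 71.6%. On these numbers compound 2 stands second of the three, beyond the scatter from both neighbours: compound 1 sits lower and compound 3 considerably higher.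

Compound 4 `CCN(Cc1ccncc1)C(=S)SCc1ccc(C(=O)Nc2ccccc2N)cc1` is not yet measured. It differs from compound 2 in one place: ethyl((pyridin-4-yl)methyl)amino in place of 1,2,3,4-tetrahydroquinolin-1-yl on a thiocarbonyl carbon. For the measured compounds named here, the only measured step, a number 57.4 percentage points higher from compound 1 to compound 3 (beyond the scatter), concerns a different place, the substituent on the ring amine nitrogen, so it does not bear directly on this change. Going by the values given here, no measured pair compares a bicyclic ring amine with an open ethyl((pyridin-4-yl)methyl)amino group on the thiocarbonyl carbon. Compound 1, the other pyridine-bearing member, gives the lowest number of the three, which gives a weak hint downward but rests on a different ring system.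

Compound 4 is therefore expected near 20%, within 5% to 45%; the estimated step is a number 6.1 percentage points lower from compound 2 to compound 4 (within the scatter), which may fall within the scatter.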

Compound 4, a percentage reported as inhibition, at one concentration (the size of the read-out at that concentration, not a potency): 63.5%
The estimate for compound 4 lay 43.5 percentage points below the measured number; the measured number lies above the stated range.
By their numbers in this assay, from the lowest: compound 1; then compound 2; then compounds 4 and 3 (each within the scatter of the next).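

In this assay the group on the thiocarbonyl carbon proves to be a sensitive position in its own right, with a number 37.4 percentage points higher from compound 2 to compound 4 (beyond the scatter). The earlier step concerned only the substituent on a ring amine nitrogen, whereas this one replaces the whole amine: 1,2,3,4-tetrahydroquinolin-1-yl gives way to the open ethyl((pyridin-4-yl)methyl)amino group, which has the same heavy-atom count and gains a hydrogen-bond acceptor. Nothing measured here explains the size of this step.

The change combines loss of the fused ring with arrival of the pyridine nitrogen, and the compounds shown do not separate the two. Also open, as far as these compounds go, is whether ethyl(benzyl)amino, with a plain benzene ring, or a propyl chain in place of the ethyl would retain the higher number.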